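Substitution on the pendant aryl of the imidazolone series

This account rests on a few compounds, and the source may have more. Where it says the series, first, only, none or still open, it means among the compounds named here.

Measured compounds:
- compound 1 `COc1cc(/C=C/C(=O)c2cccc(-n3cc(-c4ccc(Cl)cc4)[nH]c3=O)c2)cc(OC)c1OC`: 1740 nM
- compound 2 `O=C(/C=C/c1cccc(O)c1)c1cccc(-n2cc(-c3ccccc3)[nH]c2=O)c1`: 2470 nM
- compound 3 `COc1cc(/C=C/C(=O)c2cccc(-n3cc(-c4ccccc4)[nH]c3=O)c2)cc(OC)c1OC`: 310 nM

In a functional assay on MCF7 cells (Homo sapiens) for inhibition (a higher number here means a weaker inhibitor of growth, a lower number a stronger inhibitor of growth), compound 3 gives the lowest of the three numbers. Going by the values given here, compound 1 stands nearest, and the step of a 5.6-fold lower number from compound 1 to compound 3 (0.75 log units; beyond the scatter) is the only single-point change measured. Compound 2 differs from compound 3 in two places, so its value is noted only as it stands.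

Compound 4 `COc1cc(/C=C/C(=O)c2cccc(-n3cc(-c4cc(OC)c(OC)c(OC)c4)[nH]c3=O)c2)cc(OC)c1OC` is the next step from compound 3: 3,4,5-trimethoxyphenyl in place of phenyl on an aromatic carbon. Among the compounds with values here, no measured step covers this change directly. Within the data shown here, the one step that touches the same ring, from compound 1 to compound 3, shows that a substituent there carried a cost beyond the scatter, so a further substituted ring is expected to cost as well, with wide uncertainty.

Compound 4 is therefore expected to give 900 nM in this assay, between 250 nM and 3500 nM, an expected step of a 2.9-fold higher number from compound 3 to compound 4 (0.46 log units; beyond the scatter).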

Compound 4, concentration for 50% growth inhibition: 470 nM
Compound 4: middle estimate off by 1.9-fold (0.28 log units), on the high side, and the stated range covers the measured number.
By their numbers in this assay, from the lowest: compounds 3 and 4 (each within the scatter of the next); then compounds 1 and 2 (each within the scatter of the next).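

In this assay the step of a 1.5-fold higher number from compound 3 to compound 4 (0.18 log units; within the scatter) does not tell phenyl and 3,4,5-trimethoxyphenyl apart, so at this position on the five-membered aromatic ring, 12 heavy atoms in place of 6 bring no readable cost. A substituted ring therefore carries no cost as such: among the three compounds sharing the trimethoxyphenyl enone side, compound 1 with its 4-chlorophenyl is the one that lies apart, with the step of a 3.7-fold lower number from compound 1 to compound 4 (0.57 log units; beyond the scatter) as the measure. No evidence on the origin of these differences is at hand.

From the compounds shown here alone, whether a single methoxy group on this ring gives the same number as three remains open, as does whether 4-fluorophenyl would follow 4-chlorophenyl. Also open, going by these compounds, is how the position takes an aminomethyl group or a carboxylic acid on the phenyl ring.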